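From 4-methoxyphenyl to 2,5-dimethoxyphenyl in compound 2

The source may report more compounds than this note shows. Statements on the series, on what has been measured and on what is new or still open speak of the compounds shown alone.

In a functional assay on MCF7 cells (Homo sapiens) for inhibition, read by MTT assay, with a stated time of 48 h (on this read-out lower numbers stand for stronger inhibition and higher numbers for weaker inhibition), compound 1 `c1ccc(C(c2c[nH]c3ccccc23)c2c[nH]c3ccccc23)cc1` gives 22200 nM and compound 3 `COc1cccc(C(c2c[nH]c3ccc(Br)cc23)c2c[nH]c3ccc(Br)cc23)c1OC` gives 89000 nM while compound 2 `COc1ccc(C(c2c[nH]c3ccc(Br)cc23)c2c[nH]c3ccc(Br)cc23)cc1` gives 2300 nM as the lowest of the three numbers, the strongest inhibition here. Compound 4 `COc1ccc(OC)c(C(c2c[nH]c3ccc(Br)cc23)c2c[nH]c3ccc(Br)cc23)c1` is still unmeasured. Its change from compound 2 is 2,5-dimethoxyphenyl in place of 4-methoxyphenyl on a saturated chain carbon bound to two aromatic carbons and so 2,5-dimethoxyphenyl takes the place of 4-methoxyphenyl. The nearest measured guide is a 39-fold higher number from compound 2 to compound 3 (1.59 log units; beyond the scatter) and that large step also replaces 4-methoxyphenyl, there with 2,3-dimethoxyphenyl. For the measured compounds named here, no measurement yet covers 2,5-dimethoxyphenyl itself, so a higher number in this assay is expected, meaning weaker inhibition, but by a more moderate amount. The estimated step is an 8.7-fold higher number from compound 2 to compound 4 (0.94 log units; beyond the scatter) and it remains uncertain. Compound 4 is expected at 20000 nM with an estimated range from 5000 nM to 80000 nM in this measurement.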

Compound 4, half-maximal inhibitory concentration: 2800 nM
Compound 4: middle estimate off by 7.1-fold (0.85 log units), on the high side; the whole stated range lies above it.
By their numbers in this assay, from the lowest: compounds 2 and 4 (each within the scatter of the next); then compound 1; then compound 3.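

In this assay, a second methoxy group is compatible with activity in 2,5-dimethoxyphenyl, with a 1.2-fold higher number from compound 2 to compound 4 (0.09 log units; within the scatter) as the step, so the large rise seen with 2,3-dimethoxyphenyl does not follow from every second methoxy group. Exchanging one dimethoxyphenyl group for the other gives a 32-fold lower number from compound 3 to compound 4 (1.50 log units; beyond the scatter) as the step, so where the methoxy groups stand on the ring separates these two compounds, even though their count is the same. Nothing available explains this difference.

On these data alone, whether an amine or a carboxylic acid could replace a methoxy group on this ring remains open, as does the effect of a longer chain such as ethoxy.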